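Methyl in place of hydrogen on two different saturated carbons

A few compounds are considered here, and "the series" means these few. Any claim that something is new, unique, unknown or untested is made for them only; others in the source may bear on it.

The measured compounds and their values:
compound 1, `CCNc1nc(C)nc(O)c1C#N`, 2600 nM;
compound 2, `CCCNc1nc(C)nc(O)c1C#N`, 1900 nM;
compound 3, `CC(C)c1nc(O)c(C#N)c(NCc2cccnc2)n1`, 33000 nM.

All three were tested in a functional assay (muscle tissue) with Felis catus as the target; on this read-out lower numbers stand for an effect already at smaller amounts and higher numbers for an effect only at larger amounts of compound. Compound 1 and compound 2 share a core and differ by methyl in place of hydrogen on a saturated chain carbon, two bonds along the chain from a nitrogen on an aromatic ring; this change gave a 1.4-fold lower number from compound 1 to compound 2 (0.14 log units; within the scatter). Compound 3 carries a different core; the difference between the two cores is not broken down here. In this assay compound 3 gives 33000 nM, the highest of the three numbers, beyond the scatter from both compound 1 and compound 2.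

Compound 4, `CC(C)(C)c1nc(O)c(C#N)c(NCc2cccnc2)n1`, has not yet been measured. It differs from compound 3 by methyl in place of hydrogen on a saturated chain carbon bound to an aromatic carbon and two saturated chain carbons. This is the same kind of change as that from compound 1 to compound 2, but not the same: there the methyl entered on a saturated chain carbon two bonds along the chain from a nitrogen on an aromatic ring, whereas here it enters on a saturated chain carbon bound to an aromatic carbon and two saturated chain carbons. Since the earlier step gave a 1.4-fold lower number from compound 1 to compound 2 (0.14 log units; within the scatter), a step of similar size is expected here, namely a 1.2-fold lower number from compound 3 to compound 4 (0.07 log units; within the scatter). Compound 4 is accordingly estimated at 28000 nM, with a range from 10000 nM to 90000 nM, resting on the value of compound 3 in this assay, 33000 nM.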

Compound 4, half-maximal effective concentration: 55000 nM
The estimate for compound 4 lay 2.0-fold (0.29 log units) below the measured number; measured number inside the range.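

In this assay, the change from isopropyl to tert-butyl gave a 1.7-fold higher number from compound 3 to compound 4 (0.22 log units; within the scatter), so on this core, as on the core of compound 1, adding the methyl leaves the number within the usual scatter. Set beside the earlier step, the new one cannot be told apart from it: the same change on two cores in this assay, a 1.4-fold lower number (0.14 log units; within the scatter) from compound 1 to compound 2 and a 1.7-fold higher number (0.22 log units; within the scatter) from compound 3 to compound 4, 2.3-fold (0.36 log units) apart, within the scatter of two such steps. For the compounds shown here, this shows that, across these two cores, the methyl change produced no step that stands out from the scatter; it does not show that the change behaves identically on every core, since there are only two steps, the methyl enters on a different kind of saturated carbon in each, and their opposite directions cannot be read as a real difference between the cores.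

The compounds shown leave open whether a longer chain or an amine in place of the tert-butyl would move the number beyond the scatter. They also leave open whether the same methyl change would again stay within the scatter on a third core.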